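The compounds below may be only part of what the source reports. "The series", "measured", "known", "first", "only" and "open" are said of these compounds alone.

Measured in a functional assay on PC-3 cells (Homo sapiens) for inhibition, read by sulforhodamine B assay, with a stated time of 48 h, tested at 50 uM; a higher number here means more inhibition of growth at the concentration tested, a lower number less inhibition of growth:
- compound 1 `COc1cc(/C=C/C(=O)/C=C/c2cc(OC)c(OC)c(OC)c2)ccc1OCc1cn(CCOc2cc(=O)oc3ccccc23)nn1`: 22%
- compound 2 `COc1cc(/C=C/C(=O)/C=C/c2ccco2)ccc1OCc1cn(CCOc2cc(=O)oc3ccccc23)nn1`: 14%
- compound 3 `COc1ccccc1/C=C/C(=O)/C=C/c1ccc(OCc2cn(CCOc3cc(=O)oc4ccccc34)nn2)c(OC)c1`: 11%

In this assay, compound 3 gives 11%, the lowest of the three numbers, although it cannot be separated from compound 2, which gives 14%. The only clear gap is to compound 1, seen as a number 11 percentage points lower from compound 1 to compound 3 (beyond the scatter).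

The next compound is compound 4 `COc1ccc(/C=C/C(=O)/C=C/c2ccc(OCc3cn(CCOc4cc(=O)oc5ccccc45)nn3)c(OC)c2)cc1`, which carries 4-methoxyphenyl in place of 2-methoxyphenyl on a double-bonded chain carbon bound to a double-bonded chain carbon.

All three measured steps change the group at this same place. They are a number 8 percentage points lower from compound 1 to compound 2 (within the scatter), a number 3 percentage points lower from compound 2 to compound 3 (within the scatter) and a number 11 percentage points lower from compound 1 to compound 3 (beyond the scatter). Even replacing 3,4,5-trimethoxyphenyl or swapping in furan-2-yl therefore moved the number little. For the measured compounds named here, no measured pair shows a methoxy group changing place on its own, so these steps offer only a rough guide. A change that leaves the counted atoms the same is expected to give a small step, with no firm direction beyond the scatter in this assay.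

The expected outcome is a number 3 percentage points higher from compound 3 to compound 4 (within the scatter). For compound 4 the estimated value is 14%, with an expected range from 5% to 27%.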

Compound 4, percent growth inhibition at one concentration: 15%
Estimate against measurement, compound 4: 1 percentage points below, within the range that was stated.
By their numbers in this assay, from the lowest: compounds 3, 2, 4 and 1 (each within the scatter of the next, the first and the last beyond it).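

In this assay, for the compounds shown here, the exchange of 2-methoxyphenyl for 4-methoxyphenyl is the first measured pair in which the methoxy group changes place on its own, and it gives a number 4 percentage points higher from compound 3 to compound 4 (within the scatter), so these two groups cannot be told apart at this position. Going by these compounds alone, the new compound also stays within the scatter of both other groups at this place, as a number 1 percentage points higher from compound 2 to compound 4 (within the scatter) and a number 7 percentage points lower from compound 1 to compound 4 (within the scatter) show, which leaves a number 11 percentage points lower from compound 1 to compound 3 (beyond the scatter) as the only step here that clears the scatter, with 4-methoxyphenyl not separated from either end of it. Nothing available explains why these exchanges move the number so little.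

The aryl and furan-2-yl groups shown here all carry only ring carbons, methoxy groups or a ring oxygen, so it remains open whether a 4-aminophenyl, a 4-carboxyphenyl or a longer alkoxy chain on the same double-bonded chain carbon would give a step beyond the scatter. On these data alone, it is also open whether the gap between the 3,4,5-trimethoxyphenyl and 2-methoxyphenyl compounds would hold up among further groups at this place, or whether it rests on this one pair alone.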